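The source may report more compounds than this note shows. Statements on the series, on what has been measured and on what is new or still open speak of the compounds shown alone.

Compound 1, `CC(=O)Nc1cccc(NC(=O)COc2ccc3c(=O)ccoc3c2)c1`: 136 nM
Compound 2, `CCCC(=O)Nc1cccc(NC(=O)COc2ccc3c(=O)ccoc3c2)c1`: 176 nM

Among the numbers measured so far in an assay on isolated protein for inhibition of Rho-associated protein kinase 2 (Homo sapiens), read by scintillation counting, radiometric assay and 33P incorporation, with a stated time of 40 min, in the presence of a further agent that is not named here (on this read-out higher numbers stand for weaker inhibition and lower numbers for stronger inhibition), compound 2 stands highest; its nearest neighbour is compound 1, and the step of a 1.3-fold higher number from compound 1 to compound 2 (0.11 log units; within the scatter) is within the scatter, so the two cannot be told apart with confidence.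

Compound 3, `O=C(COc1ccc2c(=O)ccoc2c1)Nc1cccc(NC(=O)c2ccccc2)c1`, has not yet been measured. It differs from compound 2 in one place: phenyl in place of propyl on a carbonyl carbon. The same part of the molecule was varied once before: from compound 1 to compound 2 the group on that carbonyl carbon grew from methyl to propyl, and the number stayed within the scatter. Within the data shown here, that single step is the only measured evidence bearing on the new change, and it speaks for a carbonyl substituent that tolerates alteration without a large effect. Among the measured compounds shown here, putting a phenyl there, however, is a change of a different kind from lengthening a chain, and no measured pair covers it, so the expectation carries wide uncertainty.

For compound 3 the expected step is a 1.1-fold higher number from compound 2 to compound 3 (0.06 log units; within the scatter), with no clear direction beyond the scatter. The estimate for compound 3 is 200 nM, ranging from 60 nM to 700 nM.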

Compound 3, half-maximal inhibitory concentration: 16 nM
Estimate against measurement, compound 3: 13-fold (1.10 log units) above; measured number outside the range, below it.
By their numbers in this assay, from the lowest: compound 3; then compounds 1 and 2 (each within the scatter of the next).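

In this assay the group on this carbonyl carbon proves able to move the number a long way: the change from propyl to phenyl gives an 11-fold lower number from compound 2 to compound 3 (1.04 log units; beyond the scatter) and the change from methyl to phenyl gives an 8.5-fold lower number from compound 1 to compound 3 (0.93 log units; beyond the scatter) on the same carbon. Methyl and propyl lie within the scatter of each other, so those two chains alone made the position look insensitive, whereas a six-membered aromatic ring there stands clearly apart from both and makes compound 3 the strongest inhibitor of the three. Nothing available here explains why the phenyl group has this effect.

The compounds shown cannot separate the presence of an aromatic ring from the simple number of carbons, a question that a cyclohexyl or hexyl group on the same carbonyl carbon would address. They also leave open whether the gain survives a chlorine or methoxy group on the phenyl ring, or a pyridine ring in its place.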